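From cyclobutyl to benzyl where only limits exist

The source may report more compounds than this note shows. Statements on the series, on what has been measured and on what is new or still open speak of the compounds shown alone.

In an ADME assay on Huh-7 cells (Homo sapiens) for cytotoxicity, with a stated time of 72 h (a lower number here means that less compound is tolerated, a higher number that more compound is tolerated), compound 3 `CS(=O)(=O)Nc1ccc2c(c1)S(=O)(=O)N=C(c1c(O)c(-c3cccs3)nn(CC3(C(F)(F)F)CCC3)c1=O)N2` gives > 1000 nM as its result, which is a limit and not a number. Compound 1 `CCC(C)(C)Cn1nc(-c2cccs2)c(O)c(C2=NS(=O)(=O)c3cc(NS(C)(=O)=O)ccc3N2)c1=O` gives > 1000 nM as its result, again a limit. Compound 2 `CC(C)(C)Cn1nc(-c2cccs2)c(O)c(C2=NS(=O)(=O)c3cc(NS(C)(=O)=O)ccc3N2)c1=O` gives > 1000 nM as its result, also a limit. The whole picture is the limit of > 1000 nM in this assay, at which 3 of the 3 values shown sit, so none of the three can be ranked against the others.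

Compound 4 `CS(=O)(=O)Nc1ccc2c(c1)S(=O)(=O)N=C(c1c(O)c(-c3cccs3)nn(Cc3ccccc3)c1=O)N2` keeps the shared core of compound 3 and differs in one group: phenyl in place of 1-(trifluoromethyl)cyclobutyl on a saturated chain carbon bound to an aromatic nitrogen with phenyl in place of 1-(trifluoromethyl)cyclobutyl on a saturated chain carbon bound to an aromatic nitrogen. Read one bond further out, (1-(trifluoromethyl)cyclobutyl)methyl becomes benzyl.

For the measured compounds named here, three measured steps touch this same side chain, namely a step that the two limits leave unreadable from compound 1 to compound 2 then a step that the two limits leave unreadable from compound 1 to compound 3 and finally a step that the two limits leave unreadable from compound 2 to compound 3 and none of them has a size that can be read. None of them places a phenyl there either, so they are a weak guide. No step beyond the scatter is therefore expected in this assay and no direction can be given. The expected change is a step that the limit leaves unreadable from compound 3 to compound 4 as a rough estimate only. For compound 4 the estimated value is 3000 nM with an expected range from 1000 nM to 20000 nM and the most likely report is again only a limit.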

Compound 4, half-maximal cytotoxic concentration: > 1000 nM
Compound 4: a limit, no number; the forecaster's own chance of this, stated with the estimate: 85%; the middle value is on the limit's open side.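

In this assay compound 4 gives > 1000 nM as its result, which is a limit and not a number. Its steps to compound 1, compound 2 and compound 3 cannot be read, so the four compounds cannot be ranked: the limit of > 1000 nM in this assay, at which 4 of the 4 values shown sit. The compounds shown leave open whether these side chains differ at all in how much compound is tolerated.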